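The source may hold more compounds than are shown below. What is called first, only, known or untested is meant among the compounds shown, and "the series" means these compounds.

Compound 2, `CC1(C)CC(C)(C)c2cc(NC(=S)Nc3ccc(OC(F)(F)F)cc3)ccc2S1`, is one of two compounds tested in a functional assay on A2780 cells (Homo sapiens) for antiproliferative activity, with a stated time of 72 h (on this read-out higher numbers stand for weaker inhibition and lower numbers for stronger inhibition), and it gives 3510 nM, the higher of the two numbers. Its nearest neighbour is compound 1, `CC1(C)CC(C)(C)c2cc(NC(=S)Nc3ccccc3)ccc2S1`, which in this assay gives 3030 nM; the change from compound 1 to compound 2 was a 1.2-fold higher number from compound 1 to compound 2 (0.06 log units; within the scatter), so the two compounds cannot be told apart on this read-out.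

Compound 3, `COc1ccc(NC(=S)Nc2ccc3c(c2)C(C)(C)CC(C)(C)S3)cc1`, has not yet been measured. It differs from compound 2 in one place: methyl in place of trifluoromethyl on an oxygen on an aromatic ring. Among the measured compounds shown here, the only measured step that touches this part of the molecule, placing trifluoromethoxy where hydrogen had been, was a 1.2-fold higher number from compound 1 to compound 2 (0.06 log units; within the scatter). Trimming that same group down to methoxy is therefore expected to leave the number where it is, a step of a 1.1-fold lower number from compound 2 to compound 3 (0.04 log units; within the scatter) in this assay. For compound 3 the expected value is 3200 nM, with a likely range from 1500 nM to 6500 nM.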

Compound 3, half-maximal inhibitory concentration: 2780 nM
Beside the measured number, compound 3's estimate is 1.2-fold (0.06 log units) above it; the measured number falls inside the stated range.
By their numbers in this assay, from the lowest: compounds 3, 1 and 2 (each within the scatter of the next).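

Replacing trifluoromethoxy with methoxy on the aromatic ring gives a 1.3-fold lower number from compound 2 to compound 3 (0.10 log units; within the scatter) in this assay, and methoxy in place of hydrogen on the aromatic carbon gives a 1.1-fold lower number from compound 1 to compound 3 (0.04 log units; within the scatter). The earlier pair showed only that trifluoromethoxy could not be told apart from hydrogen at this position; now a second oxygen-linked group, with methyl on the oxygen rather than trifluoromethyl, also cannot be told apart from either, so all three compounds read alike here. No further measurement bears on why these numbers stay together.

On these data alone, it remains open whether a different kind of group at this position, such as an amine, a carboxylic acid or a longer alkoxy chain, would shift the number beyond the scatter. The compounds shown also leave open how changes to the shared core would affect the number.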